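The source may hold more compounds than are shown below. What is called first, only, known or untested is meant among the compounds shown, and "the series" means these compounds.

Measured compounds:
Compound 1 `O=C(Nc1ccc(-n2ncc3c(Br)cccc32)cc1)Nc1ccc(Cl)c(C(F)(F)F)c1`: 2000 nM
Compound 2 `CNc1cccc2c1cnn2-c1ccc(NC(=O)Nc2ccc(Cl)c(C(F)(F)F)c2)cc1`: 3000 nM

In a functional assay on HepG2 cells (Homo sapiens) for cytotoxicity, read by MTT assay, with a stated time of 72 h (a lower number here means a stronger inhibitor, a higher number a weaker inhibitor), compound 1 gives 2000 nM and compound 2 gives 3000 nM. Compound 1 holds the lowest of the two numbers, with compound 2 its nearest neighbour, but the step of a 1.5-fold higher number from compound 1 to compound 2 (0.18 log units; within the scatter) lies within the scatter, so the two compounds cannot be placed in order.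

Compound 3 `O=C(Nc1ccc(-n2ncc3ccncc32)cc1)Nc1ccc(Cl)c(C(F)(F)F)c1` is not yet measured. It differs from compound 1 in one place: a group of 9 heavy atoms (6 carbon, 3 nitrogen; one five-membered aromatic ring with 2 hetero atoms, one six-membered aromatic ring with 1 hetero atom) in place of a group of 10 heavy atoms (7 carbon, 2 nitrogen, 1 bromine; one five-membered aromatic ring with 2 hetero atoms, one six-membered aromatic ring of carbon only), on an aromatic carbon.

Within the data shown here, only one measured step exists, the exchange of bromo for methylamino on the same ring system, a 1.5-fold higher number from compound 1 to compound 2 (0.18 log units; within the scatter), and it was within the scatter. Among the measured compounds shown here, it does not test the replacement of the whole ring system, so no step known here bears directly on the change from compound 1 to compound 3. For the measured compounds named here, the one step on record gives no sign that this part of the molecule moves the number much, so no step beyond the scatter is expected in either direction.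

Compound 3 is therefore estimated at 2500 nM, with a range from 1000 nM to 6500 nM. The expected step is a 1.3-fold higher number from compound 1 to compound 3 (0.10 log units; within the scatter).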

Compound 3, half-maximal inhibitory concentration: 16000 nM
Estimate against measurement, compound 3: 6.4-fold (0.81 log units) below, outside the stated range (above it).
By their numbers in this assay, from the lowest: compounds 1 and 2 (each within the scatter of the next); then compound 3.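

Working notes on the series: in this assay, exchanging the 4-bromo-1H-indazol-1-yl group for the group of 9 heavy atoms gives an 8.0-fold higher number from compound 1 to compound 3 (0.90 log units; beyond the scatter) and so shows that this part of the molecule can move the number beyond the scatter. The earlier exchange of bromo for methylamino, a 1.5-fold higher number from compound 1 to compound 2 (0.18 log units; within the scatter), had shown no such movement, so a substituent exchange that stays within the scatter does not carry over to this larger change, in which the bromine leaves and the six-membered aromatic ring of carbon only gives way to one with 1 hetero atom. Nothing on record bears on why the number rises at this step.

The step combines both of those changes, so the compounds shown do not separate the loss of the bromine from the ring nitrogen; the 1H-indazol-1-yl group without bromine, or the group entering here with a bromine restored, would divide the two. As far as these compounds go, whether another small substituent on the carbon-only ring, such as chloro or methoxy, stays within the scatter of compound 1 also remains open.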